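The source may report more compounds than this note shows. Statements on the series, on what has been measured and on what is new or still open speak of the compounds shown alone.

Compound 2 `CC1=C(C(=O)OCc2ccccc2)C(c2cccc(O)c2)NC(=O)N1` sits at a limit in an ADME assay on CEMx174 cells (Homo sapiens) for cytotoxicity; on this read-out lower numbers stand for higher toxicity in this test and higher numbers for lower toxicity in this test: compound 2 gives > 10000 nM, which is a limit of the assay and not a number. For the measured compounds named here, its one measured neighbour, compound 1 `CC1=C(C(=O)O)C(c2cccc(O)c2)NC(=O)N1`, also sits at a limit; in this assay compound 1 gives > 10000 nM. The step that the two limits leave unreadable from compound 1 to compound 2 is thus unreadable, and the limit of > 10000 nM in this assay, at which 2 of the 2 values shown sit, is all the record offers. Compound 3 `CC1=C(C(=O)OC2CCCCC2)C(c2cccc(O)c2)NC(=O)N1` differs from compound 2 by cyclohexyl in place of benzyl on an oxygen next to a carbonyl group. No readable step bears on this change, so no move beyond the scatter is expected in this assay; the step that the limit leaves unreadable from compound 2 to compound 3 is an estimate only. Compound 3 is expected to give 15000 nM, within 5000 nM to 50000 nM.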

Compound 3, half-maximal cytotoxic concentration: > 10000 nM
Compound 3 was reported as a limit; the forecaster's own chance of this, stated with the estimate: 80%; the middle value is on the limit's open side.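

The steps among compound 1, compound 2 and compound 3 cannot be read, because each value is a limit of the assay and not a number: the limit of > 10000 nM in this assay, at which 3 of the 3 values shown sit. The compounds shown leave open whether hydrogen, benzyl and cyclohexyl on that oxygen differ at all in this assay.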